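From compound 1 to compound 4: a heteroaryl swap

This account rests on a few compounds, and the source may have more. Where it says the series, first, only, none or still open, it means among the compounds named here.

compound 1 `COc1ccc(/C=C/c2cc(C)no2)cc1OC` gives 44700 nM
compound 2 `COc1ccc(/C=C/C(=O)CC(C)=O)cc1` gives 41600 nM
compound 3 `COc1ccc(/C=C/c2cc(C)no2)cc1` gives 70200 nM

All three numbers come from an ADME assay on MDCK cells (Canis lupus familiaris) for cytotoxicity, read by MTT assay, with a stated time of 72 h (on this read-out lower numbers stand for stronger inhibition and higher numbers for weaker inhibition), and compound 1 sits in the middle of them, within the scatter of both compound 2 and compound 3.

Against compound 1, compound 4 `COc1ccc(/C=C/c2cc(C)n[nH]2)cc1OC` carries a single change (3-methyl-1H-pyrazol-5-yl in place of 3-methyl-1,2-oxazol-5-yl on a double-bonded chain carbon bound to a double-bonded chain carbon) with the rest of the core of compound 1 kept. Going by the values given here, no measured compound carries the 3-methyl-1H-pyrazol-5-yl group, so no measured step speaks to this change directly. Among the compounds with values here, the one measured step is a 1.6-fold higher number from compound 1 to compound 3 (0.20 log units; within the scatter) for hydrogen in place of methoxy on an aromatic carbon, which is a different place in the structure, and it stays within the scatter. Compound 2 has no 3-methyl-1,2-oxazol-5-yl group at all and gives 41600 nM within the scatter of compound 1 as well. Three compounds are too few for a rule, but nothing here points to a large step in this assay and no direction can be argued from them. The expected step is a 1.1-fold lower number from compound 1 to compound 4 (0.05 log units; within the scatter) and so none beyond the scatter is foreseen. Compound 4 is estimated at 40000 nM with an expected range of 16000 nM to 100000 nM in this assay on this reasoning.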

Compound 4, half-maximal inhibitory concentration: 54100 nM
Compound 4: the middle estimate sits 1.4-fold (0.13 log units) below what was measured; the measured number falls inside the stated range.
By their numbers in this assay, from the lowest: compounds 2, 1, 4 and 3 (each within the scatter of the next).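

In this assay the place on a double-bonded chain carbon bound to a double-bonded chain carbon now has a direct reading: 3-methyl-1H-pyrazol-5-yl in place of 3-methyl-1,2-oxazol-5-yl gives a 1.2-fold higher number from compound 1 to compound 4 (0.08 log units; within the scatter). The entering group counts 1 hydrogen-bond donor and 1 hydrogen-bond acceptor against 0 donors and 2 acceptors for the leaving group, at the same heavy-atom count, and this exchange leaves the step within the scatter. Nothing available bears on why the number holds at this place.

From the compounds shown here alone, whether another group at this place, such as an amine, a carboxylic acid or a longer chain, would give a step beyond the scatter stays open. Also open is whether the 3-methyl-1H-pyrazol-5-yl group would give the same reading with hydrogen in place of methoxy on the aromatic carbon, since the two single-place steps shown start from compound 1 and each covers one change alone.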